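The source may report more compounds than this note shows. Statements on the series, on what has been measured and on what is new or still open speak of the compounds shown alone.

In an ADME assay on the whole organism (strain Zucker) for pharmacokinetics, with Rattus norvegicus as the target, with stated times of 24 h and 14 days, at a dose of 3 mg/kg by the oral route (a lower number here means less compound in the circulation, a higher number more compound in the circulation at the dose given), three compounds have numbers so far:

- compound 1 `Cc1ccc(Oc2ccc3nc(COc4cccc(C(=O)O)c4)n(C)c3n2)cc1` gives 2520 ng.h/mL
- compound 2 `Cn1c(COc2cccc(C(=O)O)c2)nc2cnc(Oc3ccc4c(c3)CCC4)cc21` gives 2410 ng.h/mL
- compound 3 `Cn1c(COc2cccc(C(=O)O)c2)nc2ccc(Oc3ccc(Cl)cn3)cc21` gives 1010 ng.h/mL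

Compound 3 stands lowest of the three at 1010 ng.h/mL and the other two lie above it, beyond the usual scatter. Compound 4 `Cn1c(COc2cccc(C(=O)O)c2)nc2ccc(Oc3ncc(Cl)cc3Cl)cc21` differs from compound 3 in one place (chloro in place of hydrogen on an aromatic carbon), with chloro in place of hydrogen on an aromatic carbon, so that 5-chloropyridin-2-yl becomes 3,5-dichloropyridin-2-yl. Among the compounds with values here, no pair of measured compounds shows a single change of this kind, so the data offer no direct guide. In this assay no shift beyond the scatter is expected. The estimated step of a 1.2-fold higher number from compound 3 to compound 4 (0.07 log units; within the scatter) is small and slightly upward. Compound 4 is estimated at 1200 ng.h/mL (range 450 ng.h/mL to 3000 ng.h/mL).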

Compound 4, area under the concentration-time curve: 1400 ng.h/mL
Compound 4: middle estimate off by 1.2-fold (0.07 log units), on the low side; the measured number falls inside the stated range.
By their numbers in this assay, from the lowest: compounds 3, 4, 2 and 1 (each within the scatter of the next, the first and the last beyond it).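

Within the data shown here, this is the first single change that can be read directly in this assay: chloro in place of hydrogen on an aromatic carbon, ortho to a large group and two atoms from the ring nitrogen, gives a 1.4-fold higher number from compound 3 to compound 4 (0.14 log units; within the scatter). At this position, adding a second chloro to the 5-chloropyridin-2-yl group therefore leaves the amount of compound in the circulation level within the scatter. Nothing measured here offers an explanation for this result.

As far as these compounds go, whether fluoro, methoxy or a nitrile at this position would give a similar number remains open. So does whether this change would read the same on a different core, such as that of compound 1.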